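Replacing a Thiophene Arm with a Small Amide

The source may hold more compounds than are shown below. What is called first, only, known or untested is meant among the compounds shown, and "the series" means these compounds.

Compound 1 `Cc1c(C(C)C)c(=O)on1C(=O)N1CCCCC1`: 2 nM
Compound 2 `Cc1c(C(C)C)c(=O)on1C(=O)NC(C)(C)C`: > 1000 nM
Compound 3 `Cc1c(C(C)C)c(=O)on1C(=O)N(C)Cc1cccs1`: 2 nM

Three compounds sharing one core were tested in an assay (strain Wistar) for inhibition of Hormone-sensitive lipase (Rattus norvegicus), read by spectrophotometry; a lower number here means a stronger inhibitor, a higher number a weaker inhibitor. Compound 1 gives 2 nM and compound 3 gives 2 nM, so compound 3 stands level with compound 1 at the digits shown. For compound 2 the assay reports only a limit, > 1000 nM, and this limit is one of the values in hand (the limit of > 1000 nM in this assay, at which 1 of the 3 values shown sits). Among the compounds with values here, the single step that changes one place, an at least 500-fold higher number from compound 1 to compound 2 (2.69 log units; beyond the scatter), shows that the group on the carbonyl carbon can move the result a great deal. Compound 4 `Cc1c(C(C)C)c(=O)on1C(=O)N(C)CC(N)=O` has not yet been measured; it differs from compound 3 by carbamoyl in place of thiophen-2-yl on a saturated chain carbon bound to an amide-type nitrogen. Within the data shown here, no measured step swaps the (thiophen-2-yl)methyl group itself, so the expectation rests on the size of the earlier step: a change on the carbonyl carbon moved the number strongly, and a sizeable change is expected here as well, toward a weaker inhibitor. The expected step is a 30-fold higher number from compound 3 to compound 4 (1.48 log units; beyond the scatter). Compound 4 is estimated at 60 nM, with a range from 5 nM to 1000 nM.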

Compound 4, half-maximal inhibitory concentration: > 1000 nM
Compound 4 ended at the assay's limit; the forecaster's own chance of this, stated with the estimate: 25%; at least 16-fold (1.22 log units) between middle value and limit.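

In this assay, within the data shown here, carbamoyl in place of thiophen-2-yl on this saturated chain carbon gives an at least 500-fold higher number from compound 3 to compound 4 (2.69 log units; beyond the scatter), so the (thiophen-2-yl)methyl arm, which no earlier step changed, cannot be swapped for just any small group. Measured against the piperidine compound, the same arm gives an at least 500-fold higher number from compound 1 to compound 4 (2.69 log units; beyond the scatter), which makes (carbamoylmethyl)(methyl)amino a second group on the carbonyl carbon, after the (tert-butyl)amino of compound 2, that fails to keep the low number of compound 1 and compound 3. The value of compound 4 is a limit, not a number: the limit of > 1000 nM in this assay, at which 2 of the 4 values shown sit.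

The step from compound 2 to compound 4 cannot be read. On these data alone, whether a phenyl ring, a furan-2-yl ring or a plain ethyl chain on the same carbon would hold the low number stays open.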